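This account rests on a few compounds, and the source may have more. Where it says the series, first, only, none or still open, it means among the compounds named here.

Among the compounds with values here, in an ADME assay, at 37 degrees C, at pH 5.0 (on this read-out higher numbers stand for a longer-lived compound and lower numbers for a shorter-lived compound), compound 1 (`CC1=C(CCCCCC(=O)OCOC(=O)C(C)(C)C)C(=O)c2ccccc2C1=O`) gives 1 h and compound 2 (`COC(=O)CCCCCC1=C(C)C(=O)c2ccccc2C1=O`) gives 0.5 h as the only two numbers so far. These lie within the scatter of each other, so compound 2 has no place of its own apart from compound 1. Compound 3 (`CCCC(=O)OCOC(=O)CCCCCC1=C(C)C(=O)c2ccccc2C1=O`) has yet to be measured in this assay and departs from compound 2 by one change ((propylcarbonyl)oxy in place of hydrogen on a saturated chain carbon bound to an oxygen next to a carbonyl group) with (propylcarbonyl)oxy in place of hydrogen on a saturated chain carbon bound to an oxygen next to a carbonyl group. Within the data shown here, one measured step bears on this place, the change of ((tert-butyl)carbonyl)oxy to hydrogen, which gave a 2.0-fold lower number from compound 1 to compound 2 (0.30 log units; within the scatter) and so ran in the reverse sense. That is a single step involving a different group, which makes it only a loose guide, and no change beyond the scatter is expected in this assay for the new group. The estimated move is a 1.4-fold higher number from compound 2 to compound 3 (0.15 log units; within the scatter) and it is expected to remain within the scatter. For compound 3 the estimate is 0.7 h with an expected range from 0.3 h to 1.6 h once it is measured.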

Compound 3, half-life: 0.5 h
Compound 3: middle estimate off by 1.4-fold (0.15 log units), on the high side; measured number inside the range.
By their numbers in this assay, from the lowest: compounds 2, 3 and 1 (each within the scatter of the next).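

In this assay, adding (propylcarbonyl)oxy in place of hydrogen on a saturated chain carbon bound to an oxygen next to a carbonyl group gave no change at the digits printed from compound 2 to compound 3 (within the scatter), so this second acyl group, like the ((tert-butyl)carbonyl)oxy group before it, does not separate from the hydrogen compound on this read-out. Within the data shown here, the new comparison between the two acyl groups, propyl in place of tert-butyl on a carbonyl carbon, gave a 2.0-fold lower number from compound 1 to compound 3 (0.30 log units; within the scatter), which means that the earlier compounds' single group at this place can now be set beside a second one, and the half-lives of the two still cannot be told apart. No measurement offered here accounts for these half-lives.

From the compounds shown here alone, what remains open is whether any group at this place can move the half-life beyond the scatter, for instance a longer chain or a phenyl ring on the carbonyl carbon, or an amine carried on that chain. The compounds shown also leave open whether a carboxylic acid in place of the whole chain end would stand apart from compound 2 on this read-out.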